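The source may report more compounds than this note shows. Statements on the series, on what has been measured and on what is new or still open speak of the compounds shown alone.

Compound 1 `CC(=O)Nc1cc(-c2ccc(OC[C@@H](N)CC(C)C)c(C)c2)ccn1`: 0.08 nM in an assay on brain (strain C57BL6) for displacement of a labelled ligand from AP2-associated protein kinase 1 (Mus musculus), read by scintillation counting, with a stated time of 1 h; a lower number here means a stronger inhibitor, a higher number a weaker inhibitor
Compound 2 `CC(=O)Nc1cc(-c2ccc(OC[C@@H](N)CC(C)C)c(Cl)c2)ccn1`: 0.06 nM

Compound 2 and compound 1 stand together on these numbers, as the step of a 1.3-fold lower number from compound 1 to compound 2 (0.12 log units; within the scatter) falls within the scatter. Compound 3 `CC(=O)Nc1cc(-c2ccc(OC[C@@H](N)CC(C)C)c(OC(F)(F)F)c2)ccn1` differs from compound 2 by trifluoromethoxy in place of chloro on an aromatic carbon. For the measured compounds named here, the one measured step at this carbon, chloro in place of methyl, was itself within the scatter, and no measured step introduces a trifluoromethoxy, so no direct guide exists. A step of about a 2.0-fold higher number from compound 2 to compound 3 (0.30 log units; within the scatter) is therefore expected, with little change beyond the scatter. Compound 3 is estimated at 0.12 nM, ranging from 0.04 nM to 0.4 nM.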

Compound 3, inhibition constant: 0.04 nM
Beside the measured number, compound 3's estimate is 3.0-fold (0.48 log units) above it, within the range that was stated.
By their numbers in this assay, from the lowest: compounds 3, 2 and 1 (each within the scatter of the next).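

In this assay, trifluoromethoxy at this carbon, ortho to a (2-amino-4-methylpentyl)oxy group, gives a 1.5-fold lower number from compound 2 to compound 3 (0.18 log units; within the scatter) and a 2.0-fold lower number from compound 1 to compound 3 (0.30 log units; within the scatter) so the three groups tried here stand together. Going from chloro, with 1 heavy atom, to trifluoromethoxy, with 5 heavy atoms and 1 hydrogen-bond acceptor, moves the number by no more than the scatter. No available evidence bears on this result.

The compounds shown leave open whether an amine or a carboxylic acid at this carbon would also stay within the scatter. They also leave open how a plain hydrogen there would compare.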